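Changing the benzyl group in a ligase inhibitor series

A few compounds are considered here, and "the series" means these few. Any claim that something is new, unique, unknown or untested is made for them only; others in the source may bear on it.

Compound 1 `COc1ccccc1Cn1cc(CCCCC[C@@H]2SC[C@@H]3NC(=O)N[C@@H]32)nn1` in an assay on isolated protein for inhibition of biotin--protein ligase (Homo sapiens), read by scintillation counting, with a stated time of 10 min (a higher number here means a weaker inhibitor, a lower number a stronger inhibitor), gives > 16000 nM, which is a limit of the assay and not a number.
Compound 2 `COc1cccc(Cn2cc(CCCCC[C@@H]3SC[C@@H]4NC(=O)N[C@@H]43)nn2)c1` in this assay gives > 16000 nM, again only a limit.
Compound 3 `O=C1N[C@H]2[C@H](CS[C@H]2CCCCCc2cn(Cc3ccccc3F)nn2)N1` in this assay gives > 16000 nM, also a limit.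

Among the compounds with values here, compound 2 thus stands where every value shown stands: all three sit at the limit of > 16000 nM in this assay, at which 3 of the 3 values shown sit, so no compound can be ordered against another. Compound 4 `O=C1N[C@H]2[C@H](CS[C@H]2CCCCCc2cn(Cc3ccc(Cl)cc3)nn2)N1` has not yet been measured. It differs from compound 2 in one place: 4-chlorophenyl in place of 3-methoxyphenyl on a saturated chain carbon bound to an aromatic nitrogen. The measured steps that bear on a change of this kind are a step that the two limits leave unreadable from compound 1 to compound 2, a step that the two limits leave unreadable from compound 2 to compound 3 and a step that the two limits leave unreadable from compound 1 to compound 3; none of them has a readable size, so they point in no direction and give no sign of a step beyond the scatter. Because the three values shown all rest at the limit of > 16000 nM in this assay, at which 3 of the 3 values shown sit, the most likely outcome is that compound 4 is also reported only as a limit. Compound 4 is therefore estimated at 20000 nM, with a range from 8000 nM to 60000 nM. This estimate means an expected step that the limit leaves unreadable from compound 2 to compound 4, not expected to exceed the scatter.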

Compound 4, inhibition constant: > 16000 nM
Compound 4 ended at the assay's limit; the forecaster's own chance of this, stated with the estimate: 75%; the middle value does not contradict the limit.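

No step from compound 1, compound 2 or compound 3 to compound 4 can be read, since each value is only a limit of the assay, not a number: the limit of > 16000 nM in this assay, at which 4 of the 4 values shown sit.

The compounds shown leave open whether any benzyl group on this shared core gives a readable inhibition constant in this assay.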